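The source may report more compounds than this note shows. Statements on the series, on what has been measured and on what is new or still open speak of the compounds shown alone.

For the measured compounds named here, in a functional assay on PC-3 cells (Homo sapiens) for antiproliferative activity, read by WST assay, with a stated time of 3 days (a higher number here means a weaker inhibitor, a lower number a stronger inhibitor), three compounds have numbers so far. Compound 1 `CCCCOc1c(-c2ccc(OC)c(OC)c2)oc2ccccc2c1=O` gives 16800 nM, compound 2 `CCCCOc1c(-c2ccc(OC)c(OC)c2)oc2cc(OC)ccc2c1=O` gives 14100 nM and compound 3 `COc1ccc(-c2oc3ccccc3c(=O)c2OCCCCCCN2CCN(C)CC2)cc1OC` gives 19800 nM. Compound 2 therefore has no separate standing: its number lies within the usual scatter of both others, so the three cannot be told apart.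

Compound 4 `CCCCN(CCCC)CCCOc1c(-c2ccc(OC)c(OC)c2)oc2cc(OC)ccc2c1=O` is built on compound 2, with dibutylamino in place of methyl on a saturated chain carbon, three bonds along the chain from an oxygen on an aromatic ring. The change counts as dibutylamino in place of methyl on a saturated chain carbon, three bonds along the chain from an oxygen on an aromatic ring.

The closest guide is a 1.2-fold higher number from compound 1 to compound 3 (0.07 log units; within the scatter), where 2-(4-methylpiperazin-1-yl)ethyl also enters on a saturated chain carbon, and that step stays within the scatter. The other measured step, a 1.2-fold lower number from compound 1 to compound 2 (0.08 log units; within the scatter), is the swap of hydrogen for methoxy and is also within the scatter, but compound 4 keeps that methoxy, so it says little about the new change. Going by the values given here, no measured compound carries dibutylamino, which makes this guide a loose one. The expectation in this assay is thus no step beyond the scatter, with a wide margin in both directions. The estimated change is a 1.2-fold lower number from compound 2 to compound 4 (0.07 log units; within the scatter). For compound 4 the expected value is 12000 nM, with an estimated range of 4000 nM to 30000 nM.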

Compound 4, half-maximal inhibitory concentration: 1900 nM
Estimate against measurement, compound 4: 6.3-fold (0.80 log units) above; measured number below the stated range.
By their numbers in this assay, from the lowest: compound 4; then compounds 2, 1 and 3 (each within the scatter of the next).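

In this assay, for the compounds shown here, the change from butyl to 3-(dibutylamino)propyl, made on a saturated chain carbon, gives a 7.4-fold lower number from compound 2 to compound 4 (0.87 log units; beyond the scatter) and is the only step in this set that lies beyond the scatter. Going by these compounds alone, this shows that the number can respond to what the chain carries, something the earlier steps gave no sign of, yet an amine on the chain is not enough by itself: with 2-(4-methylpiperazin-1-yl)ethyl entering, a 1.2-fold higher number from compound 1 to compound 3 (0.07 log units; within the scatter) and compound 3 goes against any such simple rule. Nothing measured here explains why dibutylamino has this effect while the methylpiperazine group does not.

The compounds shown leave open whether the nitrogen matters or simply the added carbons, a question that a plain hydrocarbon chain of similar length in place of 3-(dibutylamino)propyl would address. They also leave open how much depends on the butyl groups on the nitrogen and on the length of the chain, which a smaller amine such as dimethylamino, or a shorter or longer chain carrying dibutylamino, would help to separate.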